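Trifluoromethyl to methyl: one change, tried a second time

The compounds below may be only part of what the source reports. "The series", "measured", "known", "first", "only" and "open" are said of these compounds alone.

Three compounds have been measured in a functional assay on MCF7 cells (Homo sapiens) for antiproliferative activity, read by MTT assay, with a stated time of 48 h; on this read-out higher numbers stand for weaker inhibition and lower numbers for stronger inhibition:

Compound 1 `Cc1ccc2[nH]c(-c3cn(-c4ccccc4)nc3-c3ccccc3)nc2c1` gives 5940 nM.
Compound 2 `FC(F)(F)c1ccc2[nH]c(-c3cn(-c4ccccc4)nc3-c3ccccc3)nc2c1` gives 2660 nM.
Compound 3 `FC(F)(F)c1ccc2[nH]c(-c3cn(-c4ccccc4)nc3-c3ccc(Cl)cc3)nc2c1` gives 4210 nM.

Compound 2 and compound 3 share a core and differ in one place: chloro in place of hydrogen on an aromatic carbon. That change gave a 1.6-fold higher number from compound 2 to compound 3 (0.20 log units; within the scatter), so the two values cannot be told apart. Compound 1 is made from compound 2 by a different change: methyl in place of trifluoromethyl on an aromatic carbon. Here the step was a 2.2-fold higher number from compound 2 to compound 1 (0.35 log units; beyond the scatter), the only step among the three that stands out from the noise of repeated measurement.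

Compound 4 `Cc1ccc2[nH]c(-c3cn(-c4ccccc4)nc3-c3ccc(Cl)cc3)nc2c1` has not yet been measured. It is made from compound 3 by methyl in place of trifluoromethyl on an aromatic carbon. This is the same change as from compound 2 to compound 1, made at the same place on the core; the only thing that differs is the surrounding of the core, which in compound 3 and compound 4 carries the chloro group described above.

With one earlier example of this change, the expectation for compound 4 rests on that example alone. Compound 4 is expected to show a 2.1-fold higher number from compound 3 to compound 4 (0.33 log units; beyond the scatter), because the same change gave a 2.2-fold higher number from compound 2 to compound 1 (0.35 log units; beyond the scatter). Such a single precedent is thin, so a wide range is allowed. Compound 4 is therefore estimated to give 9000 nM in this assay, with a plausible range from 4500 nM to 18000 nM.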

Compound 4, half-maximal inhibitory concentration: 8230 nM
For compound 4 the middle estimate is 1.1-fold (0.04 log units) above the measured one; the measured number falls inside the stated range.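

In this assay, the swap of trifluoromethyl for methyl gave a 2.0-fold higher number from compound 3 to compound 4 (0.29 log units; within the scatter) on the core that carries the chloro group; taken alone, this step cannot be told from repeat noise, but it matches the earlier step on the core without chloro: the same change on two cores in this assay, a 2.2-fold higher number (0.35 log units; beyond the scatter) from compound 2 to compound 1 and a 2.0-fold higher number (0.29 log units; within the scatter) from compound 3 to compound 4, 1.1-fold (0.06 log units) apart, within the scatter of two such steps.

The chloro change also carried over, giving a 1.4-fold higher number from compound 1 to compound 4 (0.14 log units; within the scatter) on the core with methyl, and again neither step stands out from the noise on its own: the same change on two cores in this assay, a 1.6-fold higher number (0.20 log units; within the scatter) from compound 2 to compound 3 and a 1.4-fold higher number (0.14 log units; within the scatter) from compound 1 to compound 4, 1.1-fold (0.06 log units) apart, within the scatter of two such steps.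

So across these four compounds each change behaved about the same whether or not the other was present, but this is only two cores in one cell assay, and it shows neither that the same would hold on a more different core nor why either change has the size it has.

The compounds shown leave open what other groups would do in the place of trifluoromethyl and methyl, such as a methoxy group, an amine or a carboxylic acid. They also leave open whether a fluoro group or a longer chain in place of the chloro group would follow the same pattern.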